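This account rests on a few compounds, and the source may have more. Where it says the series, first, only, none or still open, it means among the compounds named here.

Measured compounds:
compound 1 `COC(CCn1cnc2c(NCc3ccc(C(=O)Nc4ccccc4N)cc3)nc(Cl)nc21)OC` gives 11.9% in a functional assay on HCT-116 cells (Homo sapiens) for antiproliferative activity, read by CCK-8 assay, with a stated time of 72 h, tested at 8 uM; a higher number here means a stronger effect of the compound at the concentration tested, a lower number a weaker effect.
compound 2 `Nc1ccccc1NC(=O)/C=C/c1ccc(Cn2cnc3c(Nc4cccc(OC(F)(F)F)c4)nc(Cl)nc32)cc1` gives 5.23% in this assay.

Both compounds were read in this assay, and both numbers are small. The gap between compound 1 and compound 2 falls within the usual scatter of repeated measurements, so neither compound stands apart from the other; compound 1 simply sits where the other does, near the bottom of the scale.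

The next compound, compound 3 `CC(C)n1cnc2c(NCc3ccc(C(=O)Nc4ccccc4N)cc3)nc(Cl)nc21`, departs from compound 1 by one change, (isopropyl in place of 3,3-dimethoxypropyl on an aromatic nitrogen). Within the data shown here, no step between two measured compounds is known here, so nothing in the measured pair shows what such a change does. With compound 1 at 11.9% and nothing to suggest movement, the step from compound 1 to compound 3 is expected to be no larger than the scatter, a number 0.1 percentage points higher from compound 1 to compound 3 (within the scatter), in either direction. Compound 3 is therefore expected to give about 12%, within a range from 0% to 30%.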

Compound 3, a percentage reported as inhibition, at one concentration (the size of the read-out at that concentration, not a potency): 76%
Compound 3: the middle estimate sits 64 percentage points below what was measured; measured number outside the range, above it.
By their numbers in this assay, from the lowest: compounds 2 and 1 (each within the scatter of the next); then compound 3.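

Among these compounds, putting isopropyl in place of 3,3-dimethoxypropyl on the aromatic nitrogen gives a number 64.1 percentage points higher from compound 1 to compound 3 (beyond the scatter) in this assay, so the group at this position can strongly change the read-out, which the earlier compounds could not show. The change replaces a chain of 7 heavy atoms with 2 hydrogen-bond acceptors by a group of 3 heavy atoms with none, and this single step cannot separate the part played by the chain length, the branching or the two oxygens. Nothing available here accounts for the size of the step.

From the compounds shown here alone, it remains open how methyl, a straight propyl chain, cyclopentyl or a chain ending in an amine would read at this nitrogen. Going by these compounds, the read-out comes from one concentration, so the potency of compound 3 also remains open.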